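This account rests on a few compounds, and the source may have more. Where it says the series, first, only, none or still open, it means among the compounds named here.

Three analogues of the shared core have been measured in a functional assay on CHO cells for activation of 5-hydroxytryptamine receptor 1D (Homo sapiens), read by GTPgammaS binding; a lower number here means a smaller maximal response, a higher number a larger maximal response. Compound 1 `CN(Cc1cccs1)C1CCN(CCCc2c[nH]c3ccc(-n4cnnc4)cc23)CC1` gives 81%. Compound 2 `O[C@@H]1Cc2ccccc2[C@H]1NC1CCN(CCCc2c[nH]c3ccc(-n4cnnc4)cc23)CC1` gives 75% and stands second highest of the three numbers. Compound 3 `NC(=O)OC[C@H](NC1CCN(CCCc2c[nH]c3ccc(-n4cnnc4)cc23)CC1)c1ccccc1` gives 73%. Both steps among them, a number 6 percentage points lower from compound 1 to compound 2 (within the scatter) and a number 2 percentage points lower from compound 2 to compound 3 (within the scatter), stay within the scatter. Compound 4 `C[C@@H](NC1CCN(CCCc2c[nH]c3ccc(-n4cnnc4)cc23)CC1)c1ccccc1` differs from compound 2 by 1-phenylethyl in place of 2-hydroxy-2,3-dihydro-1H-inden-1-yl on an amine nitrogen. The step from compound 2 to compound 3 bears most directly on this, since it also exchanges the group on the amine nitrogen, and it was small, as was the step from compound 1 to compound 2. No step beyond the scatter in this assay is therefore expected. Compound 4 is estimated at 75%, with a range of 62% to 88%. The expected step reads no change at the digits printed from compound 2 to compound 4 (within the scatter).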

Compound 4, largest response reached (reported as efficacy), in percent of the reference or control that the assay uses: 90%
Beside the measured number, compound 4's estimate is 15 percentage points below it; the whole stated range lies below it.
By their numbers in this assay, from the lowest: compounds 3, 2, 1 and 4 (each within the scatter of the next, the first and the last beyond it).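

On an amine nitrogen, the choice of group now registers beyond the scatter: 1-phenylethyl, which carries no oxygen, gives a number 15 percentage points higher from compound 2 to compound 4 (beyond the scatter) and a number 17 percentage points higher from compound 3 to compound 4 (beyond the scatter) against the two oxygen-bearing groups. The oxygen-free methyl((thiophen-2-yl)methyl)amino group goes against any simple reading by oxygen content alone only in part, since a number 9 percentage points higher from compound 1 to compound 4 (within the scatter) leaves those two compounds unseparated. Nothing available explains these steps.

Still open, from the compounds shown here alone, is whether the gain follows the lost hydroxy group or the opened ring. The unsubstituted 2,3-dihydro-1H-inden-1-yl group would separate the two.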